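The source may hold more compounds than are shown below. What is called first, only, known or untested is meant among the compounds shown, and "the series" means these compounds.

Measured in an assay on HEK293 cells for inhibition of Voltage-dependent T-type calcium channel subunit alpha-1G (Homo sapiens), read by patch clamp (a lower number here means a stronger inhibitor, a higher number a weaker inhibitor), so far: compound 1 `CCCc1nc(-c2ccccc2)c(CNCCN2CCN(c3ccccc3Cl)CC2)o1`, 4370 nM; compound 2 `CCCc1nc(-c2ccccc2)c(CNCCN2CCN(c3ccccc3)CC2)o1`, 10300 nM; compound 3 `CCCc1nc(-c2ccccc2)c(CNCCN2CCN(c3ccc(F)cc3)CC2)o1`, 7080 nM.

Compound 3 stands second highest of the three numbers; the steps leading to it, a 1.5-fold lower number from compound 2 to compound 3 (0.16 log units; within the scatter) and a 1.6-fold higher number from compound 1 to compound 3 (0.21 log units; within the scatter), both fall within the scatter, so compound 3 is not ordered against either neighbour. Within the data shown here, the one step beyond the scatter is a 2.4-fold higher number from compound 1 to compound 2 (0.37 log units; beyond the scatter), a modest one.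

Compound 4 `CCCc1nc(-c2ccccc2)c(CNCCN2CCN(c3cccc(F)c3)CC2)o1` differs from compound 3 by 3-fluorophenyl in place of 4-fluorophenyl on an amine nitrogen in a ring. Among the measured compounds shown here, no measured step moves a fluorine about the ring; the nearest precedents, a 1.5-fold lower number from compound 2 to compound 3 (0.16 log units; within the scatter) and a 1.6-fold higher number from compound 1 to compound 3 (0.21 log units; within the scatter), stay within the scatter, so no step beyond the scatter is expected in this assay, in either direction. Compound 4 is therefore estimated at 6000 nM, range 2500 nM to 14000 nM, which would mean an expected 1.2-fold lower number from compound 3 to compound 4 (0.07 log units; within the scatter).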

Compound 4, half-maximal inhibitory concentration: 3350 nM
Estimate against measurement, compound 4: 1.8-fold (0.25 log units) above; the range from low to high includes it.
By their numbers in this assay, from the lowest: compounds 4, 1, 3 and 2 (each within the scatter of the next, the first and the last beyond it).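

Where the fluorine sits on the phenyl group makes a difference in this assay: 3-fluorophenyl in place of 4-fluorophenyl, with the same atoms, gives a step beyond the scatter (a 2.1-fold lower number from compound 3 to compound 4 (0.32 log units; beyond the scatter)). Against the unsubstituted phenyl, 3-fluorophenyl also moves beyond the scatter (a 3.1-fold lower number from compound 2 to compound 4 (0.49 log units; beyond the scatter)), whereas 4-fluorophenyl did not, and against 2-chlorophenyl it stays within the scatter (a 1.3-fold lower number from compound 1 to compound 4 (0.12 log units; within the scatter)). No measurement here explains the effect of the fluorine's placement.

On these data alone, it remains open whether 3-chlorophenyl or 3-methoxyphenyl would match 3-fluorophenyl. Also open, as far as these compounds go, is how a longer chain in place of the propyl group would change these numbers.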